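The source may hold more compounds than are shown below. What is called first, only, known or untested is meant among the compounds shown, and "the series" means these compounds.

Compound 3 `COc1cc2c(cc1OC)C(CC(=O)N1CCCC1)CC2` stands lowest of the three measured compounds in a functional assay on the whole organism (strain Wistar) for inhibition, with Rattus norvegicus as the target, read by paw edema, with stated times of 60 min and 3 h, at a dose of 100 mg/kg by the oral route (on this read-out higher numbers stand for more inhibition at the one dose given (going by the name of the read-out) and lower numbers for less inhibition), where compound 3 gives 26.1%. Compound 1 `CCN(CC)C(=O)CC1CCc2cc(OC)c(OC)cc21` gives 37.7%, and compound 2 `CCCCCNC(=O)CC1CCc2cc(OC)c(OC)cc21` gives 37.7%. Between the two larger numbers there is no change at the digits printed from compound 1 to compound 2 (within the scatter), whereas a number 11.6 percentage points lower from compound 1 to compound 3 (beyond the scatter) and a number 11.6 percentage points lower from compound 2 to compound 3 (beyond the scatter).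

Compound 4 `COc1cc2c(cc1OC)C(CC(=O)N1CCCCC1)CC2` differs from compound 3 in one place: piperidin-1-yl in place of pyrrolidin-1-yl on a carbonyl carbon. Among the compounds with values here, no measured step exchanges one ring for another on the carbonyl carbon. Within the data shown here, the steps that bear on the change are those in which pyrrolidin-1-yl replaced diethylamino or pentylamino, a number 11.6 percentage points lower from compound 1 to compound 3 (beyond the scatter) and a number 11.6 percentage points lower from compound 2 to compound 3 (beyond the scatter), both modest and downward. They place the ring-bearing amide somewhat below the two chain-bearing amides, but they say nothing about widening that ring from five members to six. The expected step of a number 3.9 percentage points higher from compound 3 to compound 4 (within the scatter) is therefore small and within the scatter. Compound 4 is estimated to give about 30%, with a likely range from 18% to 42%.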

Compound 4, a percentage reported as inhibition, in the whole organism at one dose (the size of the read-out at that dose, not a potency): 31.9%
The estimate for compound 4 lay 1.9 percentage points below the measured number, and the stated range covers the measured number.
By their numbers in this assay, from the lowest: compounds 3, 4, 1 and 2 (each within the scatter of the next, the first and the last beyond it).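

In this assay widening the ring on the carbonyl carbon, with piperidin-1-yl in place of pyrrolidin-1-yl, gives a number 5.8 percentage points higher from compound 3 to compound 4 (within the scatter), so these two rings cannot be told apart here. The piperidin-1-yl amide also stays close to both chain amides, with a number 5.8 percentage points lower from compound 2 to compound 4 (within the scatter) and a number 5.8 percentage points lower from compound 1 to compound 4 (within the scatter), so a ring on the carbonyl carbon does not by itself set an amide apart from the chain amides, although compound 3 does stand apart from them. Nothing available here offers an explanation for these numbers.

Going by these compounds, it remains open how a morpholin-4-yl ring or a larger azepan-1-yl ring would read on this carbonyl carbon, and whether a carboxylic acid in place of the amide would retain any inhibition. A single dose also leaves open how these compounds would rank across a range of doses.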